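The source may hold more compounds than are shown below. What is called first, only, known or untested is meant among the compounds shown, and "the series" means these compounds.

Measured so far in a functional assay on HeLa cells (Homo sapiens) for cytotoxicity, read by MTT assay; on this read-out lower numbers stand for stronger inhibition and higher numbers for weaker inhibition:
- compound 1 `CC[C@](C)(O)CC(=O)O[C@H](CC=C(C)C)C1=CC(=O)c2c(O)ccc(O)c2C1=O`: 30200 nM
- compound 2 `CCCC(CC(=O)O[C@H](CC=C(C)C)C1=CC(=O)c2c(O)ccc(O)c2C1=O)OC(C)=O`: 51200 nM
- compound 3 `CC(C)=CC[C@@H](OCC(C)O)C1=CC(=O)c2c(O)ccc(O)c2C1=O`: 24700 nM

Compound 2 gives the highest of the three numbers. Its nearest neighbour is compound 1, a step within the scatter; compound 3 lies further off, beyond the scatter. For the measured compounds named here, the two steps on record are small: a 1.7-fold higher number from compound 1 to compound 2 (0.23 log units; within the scatter) and a 1.2-fold lower number from compound 1 to compound 3 (0.09 log units; within the scatter) both stay within the scatter, so nothing so far moves this assay by more than noise.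

Compound 4 `CCC(O)(CC)CC(=O)O[C@H](CC=C(C)C)C1=CC(=O)c2c(O)ccc(O)c2C1=O` is not yet measured. It differs from compound 2 in one place: 1-ethyl-1-hydroxypropyl in place of 1-acetoxybutyl on a saturated chain carbon bound to a carbonyl carbon

The step from compound 1 to compound 2 is the one that bears on this change, as it exchanges a 1-hydroxy-1-methylpropyl for the same 1-acetoxybutyl and was within the scatter. Reversing that exchange, with an ethyl in place of the methyl on the carbon carrying the hydroxyl, should land close to compound 1. The step of a 1.7-fold lower number from compound 2 to compound 4 (0.23 log units; within the scatter) is therefore expected to be small and downward, not beyond the scatter. Compound 4 is estimated at 30000 nM in this assay, with a range from 12000 nM to 75000 nM.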

Compound 4, half-maximal inhibitory concentration: 52000 nM
Estimate against measurement, compound 4: 1.7-fold (0.24 log units) below; low and high end bracket the measured number.
By their numbers in this assay, from the lowest: compounds 3, 1, 2 and 4 (each within the scatter of the next, the first and the last beyond it).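

In this assay, the position on a saturated chain carbon bound to a carbonyl carbon shows no response to exchanging 1-acetoxybutyl for 1-ethyl-1-hydroxypropyl (a 1.0-fold higher number from compound 2 to compound 4 (0.01 log units; within the scatter)) or 1-hydroxy-1-methylpropyl for 1-ethyl-1-hydroxypropyl (a 1.7-fold higher number from compound 1 to compound 4 (0.24 log units; within the scatter)), so these three groups cannot be told apart here despite their different heavy-atom counts. For the compounds shown here, the only new step that clears the scatter is the modest one at the oxygen on a saturated carbon, where (2-ethyl-2-hydroxybutyl)carbonyl stands in place of 2-hydroxypropyl (a 2.1-fold higher number from compound 3 to compound 4 (0.32 log units; beyond the scatter)), whereas the earlier step between compound 1 and compound 3 at that same place stayed within the scatter. Nothing available on these compounds gives a reason for the size of any of these steps.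

As far as these compounds go, whether an amine, a carboxylic acid or a longer chain at the saturated chain carbon bound to a carbonyl carbon would move the number beyond the scatter remains open. It also remains open whether a group on the oxygen on a saturated carbon other than those shown, such as a simple methyl, would give a clearer separation in this assay.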